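The source may hold more compounds than are shown below. What is called first, only, known or untested is meant among the compounds shown, and "the series" means these compounds.

For the measured compounds named here, in a physicochemical assay, read by spectrophotometry, with a stated time of 6 min (a higher number here means a weaker inhibitor, a lower number a stronger inhibitor), compound 1 (`COc1cc(/C=N/NC(=O)CCCc2nc3ccccc3c(=O)[nH]2)ccc1O`) gives 115000000 nM and stands highest of the two numbers so far, with compound 2 (`COc1cc(/C=N/NC(=O)CCCc2nc3ccccc3c(=O)[nH]2)cc(O)c1O`) lower at 50000000 nM in the same read-out. Compound 3 (`COc1ccc(/C=N/NC(=O)CCCc2nc3ccccc3c(=O)[nH]2)cc1`) is still to be measured. It differs from compound 1 by 4-methoxyphenyl in place of 4-hydroxy-3-methoxyphenyl on a carbon with a double bond to nitrogen and so carries 4-methoxyphenyl in place of 4-hydroxy-3-methoxyphenyl on a carbon with a double bond to nitrogen. Going by the values given here, the one measured step that bears on this is a 2.3-fold lower number from compound 1 to compound 2 (0.36 log units; beyond the scatter) for hydroxy in place of hydrogen on an aromatic carbon, a modest step and a single one. Here a hydroxy leaves instead of entering, so a step of similar modest size in the opposite direction is expected in this assay toward a higher number, estimated as a 2.0-fold higher number from compound 1 to compound 3 (0.30 log units; within the scatter) for now. For compound 3 the estimated value is 230000000 nM within an expected range of 100000000 nM to 550000000 nM in this read-out.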

Compound 3, half-maximal inhibitory concentration: 180000000 nM
The estimate for compound 3 lay 1.3-fold (0.11 log units) above the measured number; the measured number falls inside the stated range.
By their numbers in this assay, from the lowest: compound 2; then compounds 1 and 3 (each within the scatter of the next).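

Working notes on the aryl group on a carbon with a double bond to nitrogen: in this assay the exchange of 4-hydroxy-3-methoxyphenyl for 4-methoxyphenyl gives a 1.6-fold higher number from compound 1 to compound 3 (0.19 log units; within the scatter) and so stays within the usual scatter of this read-out. The exchange is more than the loss of a hydroxy, since the methoxy is numbered 3 in the leaving group and 4 in the entering one, and compound 3 therefore does not simply mirror the hydroxy step seen earlier. No accompanying measurement speaks to what lies behind this result.

Still open, from the compounds shown here alone, is how far the hydroxy and the place of the methoxy each count, which 3-methoxyphenyl or 4-hydroxyphenyl at this position would separate. Also open, going by these compounds, is how an amine or a carboxylic acid on this aromatic ring would read.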